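Swapping 4-bromophenyl for 2-cyanophenyl at the limit

The source may report more compounds than this note shows. Statements on the series, on what has been measured and on what is new or still open speak of the compounds shown alone.

In a toxicity assay on NIH3T3 cells (Mus musculus) for cytotoxicity, read by resazurin assay (on this read-out lower numbers stand for an effect already at smaller amounts and higher numbers for an effect only at larger amounts of compound), compound 1 (`COC(=O)c1ccc(NCc2cncn2Cc2ccccc2F)cc1-c1ccccc1`) has the entry "not determined" (no result reported). Compound 2 (`COC(=O)c1ccc(NCc2cncn2Cc2cccc(N)c2)cc1-c1ccccc1`) gives > 10000 nM, which is a limit of the assay and not a number. Compound 3 (`COC(=O)c1ccc(NCc2cncn2Cc2ccc(Br)cc2)cc1-c1ccccc1`) gives > 10000 nM, and this too is only a limit. Compound 3 therefore has no exact position in the series, and the same is true of the two other compounds.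

Compound 4 (`COC(=O)c1ccc(NCc2cncn2Cc2ccccc2C#N)cc1-c1ccccc1`) keeps the shared core, with 2-cyanophenyl in place of 4-bromophenyl on a saturated chain carbon bound to an aromatic nitrogen.

Within the data shown here, the only measured step that bears on this change is a step that the two limits leave unreadable from compound 2 to compound 3, so its size offers no guide. The remaining evidence is the limit of > 10000 nM in this assay, at which 2 of the 3 values shown sit. Given a step that the two limits leave unreadable from compound 2 to compound 3, no step beyond the scatter is expected in this assay, and no direction can be favoured. The expected step is a step that the limit leaves unreadable from compound 3 to compound 4. For compound 4 the estimate is 15000 nM, with an expected range of 5000 nM to 40000 nM.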

Compound 4, half-maximal effective concentration: 25000 nM
Compound 4: the middle estimate sits 1.7-fold (0.22 log units) below what was measured, and the stated range covers the measured number.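

Compound 4 gives a number, but neither the step from compound 3 to compound 4 nor the step from compound 2 to compound 4 can be read, and the comparison rests only on this: the limit of > 10000 nM in this assay, at which 2 of the 4 values shown sit.

Left open is how compound 4 truly compares with compound 2 and compound 3, whose exact values remain unknown.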